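This account rests on a few compounds, and the source may have more. Where it says the series, first, only, none or still open, it means among the compounds named here.

In a functional assay on BT-549 cells (Homo sapiens) for cytotoxicity, read by sulforhodamine B assay, with a stated time of 72 h (a lower number here means a stronger inhibitor, a higher number a weaker inhibitor), compound 1 `CCS(=O)(=O)Nc1cc(-c2ccc3ncnc(Nc4ccc(F)cc4)c3c2)cnc1OC` gives 3120 nM and compound 2 `CCS(=O)(=O)Nc1cc(-c2ccc3ncnc(Nc4ccc(OC(F)(F)F)cc4)c3c2)cnc1OC` gives 8240 nM. Compound 2 therefore holds the higher of the two numbers and is the weaker inhibitor of this pair, though two compounds make only a very short scale.

The next change leads to compound 3 `CCS(=O)(=O)Nc1cc(-c2ccc3ncnc(Nc4ccc(C(=O)OC)c(OC)c4)c3c2)cnc1OC`, which carries 3-methoxy-4-(methoxycarbonyl)phenyl in place of 4-(trifluoromethoxy)phenyl on a nitrogen on an aromatic ring.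

Within the data shown here, only one measured step bears on this group: a 2.6-fold higher number from compound 1 to compound 2 (0.42 log units; beyond the scatter), a modest change beyond the scatter, made by trifluoromethoxy in place of fluoro on an aromatic carbon. Among the measured compounds shown here, no measured compound carries a methoxy or methoxycarbonyl group on this ring, so the data fix no direction for the replacement. A step of similar modest size in this assay is the most that this single precedent supports, with a slight drift back towards compound 1 at 3120 nM as a weak guess.

The expected change is a 1.4-fold lower number from compound 2 to compound 3 (0.14 log units; within the scatter), which leaves the direction open. For compound 3 the estimate is 6000 nM, with an expected range of 2000 nM to 18000 nM.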

Compound 3, half-maximal inhibitory concentration: 3760 nM
The estimate for compound 3 lay 1.6-fold (0.20 log units) above the measured number; low and high end bracket the measured number.
By their numbers in this assay, from the lowest: compounds 1 and 3 (each within the scatter of the next); then compound 2.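

In this assay, 3-methoxy-4-(methoxycarbonyl)phenyl in place of 4-(trifluoromethoxy)phenyl on a nitrogen on an aromatic ring gives a 2.2-fold lower number from compound 2 to compound 3 (0.34 log units; beyond the scatter), so the substituted ring at this position can change without a loss, even with more heavy atoms and more hydrogen-bond acceptors in the entering group. Set against 4-fluorophenyl, the same group gives a 1.2-fold higher number from compound 1 to compound 3 (0.08 log units; within the scatter), which leaves compound 1 and compound 3 level and makes compound 2, with steps beyond the scatter to both, the weakest of the three. No measurement on hand offers an explanation for this pattern.

The methoxy and methoxycarbonyl groups enter together, so the step cannot be assigned to either one alone. Also open, from the compounds shown here alone, is how a carboxylic acid or an amine in place of methoxycarbonyl would read in this assay, and whether any group on this ring can bring the number below the level shared by compound 1 and compound 3.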